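Swapping a cyclohexyl for an isobutyl-piperidine on the shared core

The compounds below may be only part of what the source reports. "The series", "measured", "known", "first", "only" and "open" are said of these compounds alone.

Measured compounds:
compound 1 `CC(C)N1CCN(c2ccc3c(c2)oc(=O)n3C(=O)NCCCCc2ccccc2)CC1` – 211 nM
compound 2 `CN1CCC(c2ccc3c(c2)oc(=O)n3C(=O)NCCCCc2ccccc2)CC1=O` – 105 nM
compound 3 `O=C(NCCCCc1ccccc1)n1c(=O)oc2cc(C3CCCCC3)ccc21` – 89 nM

Three compounds share one core and differ only in the ring attached to an aromatic carbon. In an assay on HEK293 cells for inhibition of acid ceramidase (Homo sapiens), read by fluorescence, with stated times of 10 min and 3 h (a higher number here means a weaker inhibitor, a lower number a stronger inhibitor), compound 3 gives 89 nM, the lowest number of the three. That standing rests on a 2.4-fold lower number from compound 1 to compound 3 (0.37 log units; beyond the scatter), which is modest but beyond the scatter, while a 1.2-fold lower number from compound 2 to compound 3 (0.07 log units; within the scatter) is within the scatter, so compound 2 and compound 3 cannot be told apart on these numbers.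

Compound 4 `CC(C)CN1CCC(c2ccc3c(c2)oc(=O)n3C(=O)NCCCCc2ccccc2)CC1` is not yet measured. Its change is 1-isobutylpiperidin-4-yl in place of cyclohexyl on an aromatic carbon. For the measured compounds named here, two measured steps bear on it. The step from the nitrogen-bearing ring of compound 1 to the cyclohexyl of compound 3 was modest, a 2.4-fold lower number from compound 1 to compound 3 (0.37 log units; beyond the scatter); the step from the piperidine ring of compound 2 to the same cyclohexyl was within the scatter, a 1.2-fold lower number from compound 2 to compound 3 (0.07 log units; within the scatter). Going the other way, from cyclohexyl back to a nitrogen-bearing six-membered ring, a small rise in the number or none beyond the scatter is therefore expected in this assay.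

For compound 4 the expected step is a 1.3-fold higher number from compound 3 to compound 4 (0.13 log units; within the scatter). Compound 4 is estimated at 120 nM, with a range from 50 nM to 280 nM.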

Compound 4, half-maximal inhibitory concentration: 120 nM
The estimate for compound 4 equals the measured number at the digits printed, and the stated range covers the measured number.
By their numbers in this assay, from the lowest: compounds 3, 2, 4 and 1 (each within the scatter of the next, the first and the last beyond it).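

In this assay, this position on the aromatic carbon accepts 1-isobutylpiperidin-4-yl, a larger group than cyclohexyl that brings a ring nitrogen and a branched chain, with no change that can be told from noise: a 1.3-fold higher number from compound 3 to compound 4 (0.13 log units; within the scatter). The new compound also cannot be separated from either nitrogen-bearing comparator, with a 1.1-fold higher number from compound 2 to compound 4 (0.06 log units; within the scatter) and a 1.8-fold lower number from compound 1 to compound 4 (0.25 log units; within the scatter), so it sits within the scatter of all three earlier compounds, even though compound 1 and compound 3 lie beyond the scatter of each other. This shows that the position tolerates a ring nitrogen carrying an isobutyl group, and no measurement shown here gives a reason for this tolerance.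

Going by these compounds, all four groups are six-membered non-aromatic rings, so it remains open whether a flat phenyl ring, an open-chain amine or a carboxylic acid at this position would shift the number beyond the scatter. It is also unclear whether a piperidine with only a hydrogen on its nitrogen would stay level with compound 4 in this assay, which would show whether the isobutyl group matters here at all.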